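The source may hold more compounds than are shown below. What is called first, only, known or untested is meant among the compounds shown, and "the series" means these compounds.

Compound 1 `Clc1ccc(C2=NN(C3=NC(c4ccccc4)CS3)C(c3ccc4ccccc4c3)C2)cc1` gives 7560 nM in a functional assay on HeLa cells (Homo sapiens) for inhibition, read by CCK-8 assay, with a stated time of 48 h; a higher number here means a weaker inhibitor, a lower number a stronger inhibitor.
Compound 2 `O=C1CSC(N2N=C(c3ccc(Cl)cc3)CC2c2cccc3ccccc23)=N1` gives 8840 nM in this assay.
Compound 3 `Clc1ccc(C2=NN(C3=NC(c4ccccc4)CS3)C(c3cccc4ccccc34)C2)cc1` gives 9940 nM in this assay.

Compound 3 has the highest of the three numbers, but its neighbours sit close: the step of a 1.3-fold higher number from compound 1 to compound 3 (0.12 log units; within the scatter) and the step of a 1.1-fold higher number from compound 2 to compound 3 (0.05 log units; within the scatter) both stay within the scatter, so the three compounds cannot be ordered on these numbers.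

Compound 4 `c1ccc(C2=NN(C3=NC(c4ccccc4)CS3)C(c3cccc4ccccc34)C2)cc1` has not yet been measured. It differs from compound 3 in one place: hydrogen in place of chloro on an aromatic carbon. The change sits on an aromatic carbon of a six-membered aromatic ring of carbon only, para to a large group.

Among the measured compounds shown here, none of the measured steps touches this place. The two steps that are known, from compound 1 to compound 3 and from compound 2 to compound 3, change other parts of the structure, and both were within the scatter. There is therefore nothing in the data that points to a step beyond the scatter in this assay in either direction, and the expected step of a 1.2-fold higher number from compound 3 to compound 4 (0.08 log units; within the scatter) is small, with the uncertainty that comes from an unexplored change.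

Compound 4 is thus expected to give about 12000 nM in this assay, with a range of 5000 nM to 30000 nM.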

Compound 4, half-maximal inhibitory concentration: 5320 nM
Compound 4: middle estimate off by 2.3-fold (0.35 log units), on the high side, within the range that was stated.
By their numbers in this assay, from the lowest: compounds 4, 1, 2 and 3 (each within the scatter of the next).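

The first change made at this place, 4-chlorophenyl to phenyl, gives a 1.9-fold lower number from compound 3 to compound 4 (0.27 log units; within the scatter) in this assay. Taking away the chloro on this aromatic carbon, para to a large group, therefore leaves compound 4 not separable from compound 3, which shows that the chlorine atom is not required for the micromolar-range inhibition of HeLa cells seen in this small set, although this step is the largest of the three steps shown so far. Nothing measured here accounts for the size of this step, and no supporting data bear on it.

From the compounds shown here alone, it remains open whether any other group on this aromatic carbon, such as methoxy, an amine, a carboxylic acid or a longer alkyl chain, would carry the number beyond the scatter in either direction. Going by these compounds, it is also open whether the same change from chloro to hydrogen would behave alike with the naphthalen-2-yl group of compound 1 or with the ring carbonyl of compound 2 in place.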